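Replacing a Halogenated Phenyl on a Shared Core

The source may report more compounds than this note shows. Statements on the series, on what has been measured and on what is new or still open speak of the compounds shown alone.

Three compounds share a core and differ only in the aryl group attached to it. Compound 1 `CCCS(=O)(=O)Nc1ccc(F)c(C(=O)c2n[nH]c3ncc(-c4ccc(C)cc4)cc23)c1F` gives 5.4% in an assay for binding affinity to dual specificity mitogen-activated protein kinase kinase 4 (Homo sapiens), read by KINOMEscan, tested at 100 nM; on this read-out higher numbers stand for a weaker effect at the one concentration tested and lower numbers for a stronger effect. Compound 2 `CCCS(=O)(=O)Nc1ccc(F)c(C(=O)c2n[nH]c3ncc(-c4ccc(N(C)C)cc4)cc23)c1F` gives 2.5% in this assay, and compound 3 `CCCS(=O)(=O)Nc1ccc(F)c(C(=O)c2n[nH]c3ncc(-c4ccc(Cl)c(C(F)(F)F)c4)cc23)c1F` gives 15% in this assay. Compound 3 has the highest of the three numbers: its nearest neighbour is compound 1, with a number 9.6 percentage points higher from compound 1 to compound 3 (within the scatter), and its furthest is compound 2, with a number 12.5 percentage points higher from compound 2 to compound 3 (beyond the scatter). Compound 4 `CCCS(=O)(=O)Nc1ccc(F)c(C(=O)c2n[nH]c3ncc(-c4ccc(S(=O)(=O)NC)cc4)cc23)c1F` has not yet been measured; it differs from compound 3 in one place: 4-(methylsulfamoyl)phenyl in place of 4-chloro-3-(trifluoromethyl)phenyl on an aromatic carbon. Among the compounds with values here, both measured steps that end at compound 3 bear on this change, since each exchanges the same 4-chloro-3-(trifluoromethyl)phenyl for another aryl group; only the one from compound 2 lies beyond the scatter. Within the data shown here, the entering 4-(methylsulfamoyl)phenyl has no measured counterpart, so the expectation rests on those two steps alone. Compound 4 is therefore expected to show a modest downward step, a number 8 percentage points lower from compound 3 to compound 4 (within the scatter) in this assay, which may still fall within the scatter. The estimate for compound 4 is 7%, with a range from 1.5% to 22%.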

Compound 4, a percentage reported as activity, at one concentration (the size of the read-out at that concentration, not a potency): 1.2%
The estimate for compound 4 lay 5.8 percentage points above the measured number; the whole stated range lies above it.
By their numbers in this assay, from the lowest: compounds 4, 2, 1 and 3 (each within the scatter of the next, the first and the last beyond it).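

In this assay, this position accepts the 4-(methylsulfamoyl)phenyl, which brings a hydrogen-bond donor and two hydrogen-bond acceptors that the group it replaces lacks, and the change from the 4-chloro-3-(trifluoromethyl)phenyl is a step beyond the scatter (a number 13.8 percentage points lower from compound 3 to compound 4 (beyond the scatter)). The reading cannot be told apart from those with the smaller methyl or dimethylamino substituents in its place (a number 4.2 percentage points lower from compound 1 to compound 4 (within the scatter); a number 1.3 percentage points lower from compound 2 to compound 4 (within the scatter)), so a methylsulfamoyl group does not cost binding here, while compound 3 stands apart from compound 2 and compound 4 but not from compound 1. No measurement explains why these readings differ.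

On these data alone, it remains open whether a carboxylic acid or a morpholine on the same phenyl ring would read alike. Readings at one concentration also leave open whether compounds 1, 2 and 4 would show a stronger or weaker effect than one another at any other concentration.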